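The compounds below may be only part of what the source reports. "The series", "measured", "known", "first", "only" and "open" are said of these compounds alone.

Compound 1 `N#Cc1cnc(NC(=O)CCCOc2ccccc2)s1` gives 0.15 h
Compound 2 `CC(C)c1cnc(NC(=O)CCCOc2ccccc2)s1` gives 0.117 h
Compound 3 `Cc1cnc(NC(=O)CCCOc2ccccc2)s1` gives 0.167 h

These half-lives come from an ADME assay on microsomes from liver (Homo sapiens) for metabolic stability, read by LC-MS, using NADPH, tested at 1 uM (a lower number here means that the compound disappears faster, a higher number that the compound lasts longer), and cannot be told apart, so compound 1 stands level with the other two. The measured steps are a 1.3-fold lower number from compound 1 to compound 2 (0.11 log units; within the scatter) and a 1.1-fold higher number from compound 1 to compound 3 (0.05 log units; within the scatter) as well as a 1.4-fold higher number from compound 2 to compound 3 (0.15 log units; within the scatter) in this set. Compound 4 `N#Cc1cnc(NC(=O)CCCOc2cccc(C(F)(F)F)c2)s1` has trifluoromethyl in place of hydrogen on an aromatic carbon in the structure of compound 1. All three measured steps exchange cyano, isopropyl or methyl on a different aromatic carbon, so they guide only weakly. No step beyond the scatter is expected, in either direction. The estimated result is a 1.2-fold higher number from compound 1 to compound 4 (0.08 log units; within the scatter) for this change. For compound 4 the expected half-life is 0.18 h with an estimated range from 0.09 h to 0.4 h in this measurement.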

Compound 4, half-life: 1.33 h
Compound 4: middle estimate off by 7.4-fold (0.87 log units), on the low side; the measured number lies above the stated range.
By their numbers in this assay, from the lowest: compounds 2, 1 and 3 (each within the scatter of the next); then compound 4.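

In this assay, trifluoromethyl in place of hydrogen on the six-membered aromatic ring of carbon only gives an 8.9-fold higher number from compound 1 to compound 4 (0.95 log units; beyond the scatter) and so lies beyond the scatter, while the three exchanges among cyano, isopropyl and methyl on a different aromatic carbon all stayed within it. This ring position can therefore shift the half-life, at least with this group. Nothing here gives a measured reason for the step. Going by these compounds, whether a single fluorine atom, a methoxy group or an amine at this place would give a step of similar size stays open. So does whether the same gain would appear with isopropyl or methyl in place of cyano.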